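This account rests on a few compounds, and the source may have more. Where it says the series, first, only, none or still open, it means among the compounds named here.

Of the compounds shown here, three that share one core have been tested in a functional assay on A549 cells (Homo sapiens) for antiproliferative activity, read by MTT assay, with a stated time of 24 h; on this read-out lower numbers stand for stronger inhibition and higher numbers for weaker inhibition. Compound 1 `O=C(NNc1cccc(Cl)c1)c1cccc(NS(=O)(=O)c2cnc(O)nc2O)c1` gives 6640 nM and compound 3 `O=C(NNC(=O)c1ccccc1F)c1ccc(NS(=O)(=O)c2cnc(O)nc2O)cc1` gives 7610 nM, two values within the usual scatter of each other. Compound 2 `Cc1ccc(C(=O)NNC(=O)c2ccc(NS(=O)(=O)c3cnc(O)nc3O)cc2)cc1` gives 15900 nM, a higher number than either, so compound 1 sits at the stronger end of this small set, level with compound 3.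

Compound 4 `O=C(NNC(=O)c1ccccc1Cl)c1cccc(NS(=O)(=O)c2cnc(O)nc2O)c1` has not yet been measured. It carries (2-chlorophenyl)carbonyl in place of 3-chlorophenyl on an amine nitrogen. Going by the values given here, no measured step covers this change directly. The closest evidence is a 2.1-fold lower number from compound 2 to compound 3 (0.32 log units; beyond the scatter), a modest step in which 2-fluorophenyl replaces 4-methylphenyl on a carbonyl carbon. It is a single step, but it suggests that swapping the group on that carbonyl need not move the number far. Compound 4 also has a phenyl ring on a carbonyl carbon, and the two measured compounds of that kind, compound 3 at 7610 nM and compound 2 at 15900 nM, do not fall below compound 1. Little or no change beyond the scatter is therefore expected, with a slight lean towards a higher number. The expected change is a 1.4-fold higher number from compound 1 to compound 4 (0.13 log units; within the scatter). For compound 4 the estimated value is 9000 nM, with an expected range of 4000 nM to 19000 nM.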

Compound 4, half-maximal inhibitory concentration: 3740 nM
Beside the measured number, compound 4's estimate is 2.4-fold (0.38 log units) above it; measured number below the stated range.
By their numbers in this assay, from the lowest: compounds 4, 1 and 3 (each within the scatter of the next, the first and the last beyond it); then compound 2.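

In this assay the exchange of (3-chlorophenyl)amino for ((2-chlorophenyl)carbonyl)amino gives a 1.8-fold lower number from compound 1 to compound 4 (0.25 log units; within the scatter) and so stays inside the usual scatter, which leaves compound 1 and compound 4 level with each other. Going by these compounds alone, this is the first direct look at this amine nitrogen: the earlier step only exchanged one group for another on a carbonyl carbon, whereas here a carbonyl, with its added hydrogen-bond acceptor, enters the linking part of the molecule, and the number still shows no change that can be told from scatter. Nothing in the data shown offers a reason for this result.

This single step changes two things at once, the new carbonyl and the place of the chlorine on the ring, so the compounds shown cannot say what either does alone, and a 3-chlorophenyl group on the same carbonyl would be the natural way to separate them. From the compounds shown here alone, it also remains open how this amine nitrogen would respond to a group of a different kind, such as a simple acetyl group, a longer alkyl chain or a chain ending in an amine.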